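Thiophen-2-yl to 3-fluorobenzyl: notes on the series

The source may hold more compounds than are shown below. What is called first, only, known or untested is meant among the compounds shown, and "the series" means these compounds.

Measured in a functional assay on HL-60 cells (Homo sapiens) for inhibition, read by CCK-8 assay, with a stated time of 48 h, tested at 20 uM (a higher number here means more inhibition of growth at the concentration tested, a lower number less inhibition of growth), so far
- compound 1 (`COc1ccc(S(=O)(=O)Oc2ccccc2/C=C(\C#N)C(=O)Nc2nnc(-c3cccs3)s2)cc1`) gives 67%
- compound 2 (`N#C/C(=C\c1ccccc1OS(=O)(=O)c1ccc([N+](=O)[O-])cc1)C(=O)Nc1nnc(-c2cccs2)s1`) gives 23%
- compound 3 (`Cc1nnc(NC(=O)/C(C#N)=C/c2cccc(OS(C)(=O)=O)c2)s1`) gives 20%

Compound 1 stands highest of the three, and compound 2 and compound 3 both lie well under it. The next compound to consider is compound 4 (`COc1ccc(S(=O)(=O)Oc2ccccc2/C=C(\C#N)C(=O)Nc2nnc(Cc3cccc(F)c3)s2)cc1`). The structural change is 3-fluorobenzyl in place of thiophen-2-yl on an aromatic carbon and amounts to 3-fluorobenzyl in place of thiophen-2-yl on an aromatic carbon of a five-membered aromatic ring with 2 nitrogen and 1 sulfur.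

Among the measured compounds shown here, the only measured step in one place is a number 44 percentage points lower from compound 1 to compound 2 (beyond the scatter) and it is large. That step, however, is nitro in place of methoxy, elsewhere in the molecule, and compound 4 keeps the methoxy. It shows that one substitution can move this series a long way, but it gives no direct guide to the present change. Compound 3 carries another group at this place but also differs elsewhere, so its 20% cannot be read as a step. No step beyond the scatter is therefore expected, only a slight downward lean with wide margins. The expected change is a number 7 percentage points lower from compound 1 to compound 4 (within the scatter) in this assay on this reasoning. The estimate for compound 4 is 60% with an expected range from 35% to 85% in these notes.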

Compound 4, percent growth inhibition at one concentration: 100%
For compound 4 the middle estimate is 40 percentage points below the measured one, outside the stated range (above it).
By their numbers in this assay, from the lowest: compounds 3 and 2 (each within the scatter of the next); then compound 1; then compound 4.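

In this assay the aromatic carbon next to the ring nitrogen and next to the ring sulfur proves to be a place of real weight: a number 33 percentage points higher from compound 1 to compound 4 (beyond the scatter), with the rest of the molecule unchanged. Among the compounds shown here, the only step readable earlier lay elsewhere in the molecule and ran downward, so this is the first readable step at this place and the first beyond the scatter to run upward. Thiophen-2-yl is also not needed for growth inhibition in this series, since with 3-fluorobenzyl in its place compound 4 gives 100% and the methoxy stays as it was. No measurement on hand accounts for the rise.

The change alters the ring, adds the fluorine and inserts a carbon link all at once, so the compounds shown cannot say which of these carries the step; an unsubstituted benzyl or a 3-fluorophenyl group at this place would begin to separate them. Also open, from the compounds shown here alone, is whether nitro in place of methoxy would lower the number as far on the 3-fluorobenzyl compound as it does on the thiophen-2-yl pair.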